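The compounds below may be only part of what the source reports. "The series", "measured", "known", "first", "only" and "open" are said of these compounds alone.

Of the compounds shown here, two with a shared core have been measured in a functional assay on HEK293 cells for agonist activity at G-protein coupled receptor 39 (Homo sapiens), read by scintillation proximity assay and inositol phosphate accumulation, with a stated time of 75 min; a lower number here means that less compound is needed, a higher number that more compound is needed for the effect. Compound 1 `Cc1nn(-c2ncnc3nc[nH]c23)c2c1C(OCc1ccccc1F)CC(=O)N2` gives 78 nM. Compound 2 `Cc1nn(-c2ncnc3nc[nH]c23)c2c1C(NC(=O)Cc1cccs1)CC(=O)N2` gives 244 nM, the highest of the two numbers, and the step of a 3.1-fold higher number from compound 1 to compound 2 (0.50 log units; beyond the scatter) separates them. Compound 3 `Cc1nn(-c2ncnc3nc[nH]c23)c2c1C(OCc1ccc(F)cc1)CC(=O)N2` differs from compound 2 by (4-fluorobenzyl)oxy in place of (((thiophen-2-yl)methyl)carbonyl)amino on a saturated ring carbon. This largely reverses the change made between compound 1 and compound 2, so the step of a 3.1-fold higher number from compound 1 to compound 2 (0.50 log units; beyond the scatter) is the one that bears on it, and a return toward the number of compound 1 is expected. For compound 3 the estimate is 100 nM, with a range from 40 nM to 250 nM, meaning an expected step of a 2.4-fold lower number from compound 2 to compound 3 (0.39 log units; beyond the scatter).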

Compound 3, half-maximal effective concentration: 126 nM
For compound 3 the middle estimate is 1.3-fold (0.10 log units) below the measured one, within the range that was stated.
By their numbers in this assay, from the lowest: compounds 1, 3 and 2 (each within the scatter of the next, the first and the last beyond it).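

Placing (4-fluorobenzyl)oxy on this saturated ring carbon in place of (((thiophen-2-yl)methyl)carbonyl)amino gives a 1.9-fold lower number from compound 2 to compound 3 (0.29 log units; within the scatter) and so cannot be told apart from repeat-measurement scatter. Exchanging 2-fluorophenyl for 4-fluorophenyl gives a 1.6-fold higher number from compound 1 to compound 3 (0.21 log units; within the scatter) and likewise shows no clear effect of where the fluorine sits on this ring. No supporting data explain these numbers. Still open, going by these compounds, is how a plain benzyloxy group without fluorine would compare with these groups. An amine on the same carbon is also untested among the compounds shown here.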